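A Second Methyl on Compound 2

The source may hold more compounds than are shown below. What is called first, only, known or untested is meant among the compounds shown, and "the series" means these compounds.

Of the compounds shown here, two have numbers so far in a functional assay on MCF7 cells (Homo sapiens) for inhibition, read by CCK-8 assay, with a stated time of 72 h; on this read-out lower numbers stand for stronger inhibition and higher numbers for weaker inhibition. Compound 1 (`O=C(/C=C/c1cccnc1)NCCCCCCCc1ccc(S(=O)(=O)Nc2ccccc2)cc1`) gives 37.6 nM. Compound 2 (`Cc1ccccc1NS(=O)(=O)c1cccc(CCCCCCNC(=O)/C=C/c2cccnc2)c1`) gives 0.226 nM, the lower of the two numbers, and the gap between them lies beyond the usual scatter. These two compounds differ in more than one place, so their gap does not isolate any single change.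

Compound 3 (`Cc1ccc(C)c(NS(=O)(=O)c2cccc(CCCCCCNC(=O)/C=C/c3cccnc3)c2)c1`) departs from compound 2 in one place: methyl in place of hydrogen on an aromatic carbon. This is methyl in place of hydrogen on an aromatic carbon, para to a methyl group, which turns 2-methylphenyl into 2,5-dimethylphenyl.

Among the measured compounds shown here, no measured step covers such a change, so the expectation rests on compound 2 at 0.226 nM and on the small size of the change. The expected step of a 1.3-fold higher number from compound 2 to compound 3 (0.12 log units; within the scatter) leans slightly toward weaker inhibition and is not expected to go beyond the scatter. For compound 3 in this assay the estimated value is 0.3 nM, with an expected range of 0.08 nM to 1.2 nM.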

Compound 3, half-maximal inhibitory concentration: 0.6 nM
Compound 3: the middle estimate sits 2.0-fold (0.30 log units) below what was measured; the measured number falls inside the stated range.
By their numbers in this assay, from the lowest: compound 2; then compound 3; then compound 1.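

In this assay, among the compounds shown here, the change from 2-methylphenyl to 2,5-dimethylphenyl gives the first step that isolates a single change: a 2.7-fold higher number from compound 2 to compound 3 (0.42 log units; beyond the scatter). This carbon, para to a methyl group, is therefore not a silent place for substitution, since one added methyl moves the number beyond the scatter, though only modestly. The added methyl also leaves strong inhibition in place, with compound 3 at 0.6 nM, but nothing available explains the direction or the size of this step.

A single step at a single carbon leaves open whether the rise belongs to methyl itself or would appear with other groups at this place, such as a fluorine, a methoxy or an amine. It also leaves open whether the same methyl would give a similar step on a core with a longer chain, or with the methyl group of the 2-methylphenyl absent, so the step cannot yet be read as a rule for the series.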